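Chloro in Place of Methoxy: Where Compound 3 Might Land

A few compounds are considered here, and "the series" means these few. Any claim that something is new, unique, unknown or untested is made for them only; others in the source may bear on it.

compound 1 `O=C(/C=C/c1ccccc1)NNC(=O)c1ccccc1O` — 20100 nM
compound 2 `COCOc1cc(/C=C/C(=O)OCC(=O)Nc2ccc(OC)cc2)ccc1OCc1ccccc1` — > 200000 nM

In a functional assay on LS174T cells (Homo sapiens) for cytotoxicity, read by MTT assay, with a stated time of 72 h (on this read-out higher numbers stand for weaker inhibition and lower numbers for stronger inhibition), compound 1 gives 20100 nM. Compound 2 sits at the limit of > 200000 nM in this assay, at which 1 of the 2 values shown sits, a boundary of the assay rather than a number. Of the two values shown, compound 2 therefore stands at the weak end.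

Compound 3 `COCOc1cc(/C=C/C(=O)OCC(=O)Nc2ccc(Cl)cc2)ccc1OCc1ccccc1` differs from compound 2 by chloro in place of methoxy on an aromatic carbon. Within the data shown here, no step between measured compounds is at hand, so the expected step, a number no higher from compound 2 to compound 3 (the limit leaves the size open), is no larger than the scatter. Compound 3 is expected to give 200000 nM in this assay, within 70000 nM to 500000 nM, and most likely once more reported only as a limit.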

Compound 3, half-maximal inhibitory concentration: > 200000 nM
Compound 3: only a limit was reported (the forecaster's own chance of this, stated with the estimate: 70%); the middle value sits exactly at the limit.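

Compound 2 and compound 3 both stop at a limit rather than a number, so no step can be read between them: the limit of > 200000 nM in this assay, at which 2 of the 3 values shown sit.

As far as these compounds go, how far either compound lies beyond that limit, and whether chloro and methoxy differ here at all, stays open.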